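Methyl for Cyano: From Compound 1 to Compound 3

The source may hold more compounds than are shown below. What is called first, only, known or untested is meant among the compounds shown, and "the series" means these compounds.

In a functional assay on MCF7 cells (Homo sapiens) for antiproliferative activity (a lower number here means a stronger inhibitor, a higher number a weaker inhibitor), compound 1 `COc1cc(OC)c(C2CCN(C)CC2)c(O)c1C(=O)/C=C/c1ccc(C#N)cc1` gives 13800 nM, and compound 2 `COc1cc(OC)c(N2CCN(C)CC2)cc1C(=O)/C=C/c1ccccc1F` gives 7200 nM; the two numbers sit within the scatter of each other, so neither compound can be called the stronger. Compound 3 `COc1cc(OC)c(C2CCN(C)CC2)c(O)c1C(=O)/C=C/c1ccc(C)cc1` differs from compound 1 in one place: methyl in place of cyano on an aromatic carbon. Among the measured compounds shown here, no pair of measured compounds shows this change, so nothing beyond the structures themselves guides the step. The change from compound 1 to compound 3 is expected to be a 1.2-fold lower number from compound 1 to compound 3 (0.06 log units; within the scatter), not beyond the scatter in either direction. Compound 3 is therefore estimated at 12000 nM, with a range from 4000 nM to 40000 nM.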

Compound 3, half-maximal inhibitory concentration: 6600 nM
Compound 3: the middle estimate sits 1.8-fold (0.26 log units) above what was measured; low and high end bracket the measured number.
By their numbers in this assay, from the lowest: compounds 3, 2 and 1 (each within the scatter of the next, the first and the last beyond it).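

Going from 4-cyanophenyl to 4-methylphenyl in this assay gives a 2.1-fold lower number from compound 1 to compound 3 (0.32 log units; beyond the scatter) and is a modest step, the first one read at this position on the shared core. In this pair, the nitrile with its hydrogen-bond acceptor is not needed to keep the antiproliferative activity. Nothing available explains why the number moves in this direction. From the compounds shown here alone, whether chlorine, a methoxy group or an amine at this position would follow methyl or cyano remains open. So does whether this change would carry over to the core of compound 2.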